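Chain length at the amide of a benzophenone core

A few compounds are considered here, and "the series" means these few. Any claim that something is new, unique, unknown or untested is made for them only; others in the source may bear on it.

Measured compounds:
Compound 1, `CCCCCC(=O)NCC(=O)N(C)c1ccc(Cl)cc1C(=O)c1ccccc1Cl`: 1.9 mg/kg
Compound 2, `CCCCC(=O)NCC(=O)N(C)c1ccc(Cl)cc1C(=O)c1ccccc1Cl`: 1.3 mg/kg

For the measured compounds named here, in a functional assay on the whole organism for antagonist activity, with Mus musculus as the target (a higher number here means that more compound is needed for the effect, a lower number that less compound is needed), compound 2 gives the lower of the two numbers, and its only neighbour is compound 1, whose value lies within the scatter of it. Compound 3, `CCCCCCCCCCCCCCCC(=O)NCC(=O)N(C)c1ccc(Cl)cc1C(=O)c1ccccc1Cl`, is the next compound, not yet measured in this assay. Its change from compound 2 is undecyl in place of hydrogen on a saturated chain carbon, four bonds along the chain from a carbonyl carbon. Going by the values given here, the one measured step that bears on it, a 1.5-fold lower number from compound 1 to compound 2 (0.16 log units; within the scatter), changes the same chain by a single carbon and stays within the scatter. Among the compounds with values here, the move to compound 3 adds far more chain than that step covers, so no measured step truly anticipates it; the small shift seen leaves the direction open. Compound 3 is therefore expected, with wide uncertainty, to give 4 mg/kg in this assay, between 1.3 mg/kg and 15 mg/kg, a step of a 3.1-fold higher number from compound 2 to compound 3 (0.49 log units; beyond the scatter).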

Compound 3, dose for half-maximal effect: > 100 mg/kg
Compound 3 gave a limit, no number; the forecaster's own chance of this, stated with the estimate: 20%; at least 25-fold (1.39 log units) between middle value and limit.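

In this assay, compound 3 gives a limit of the assay and not a number: the limit of > 100 mg/kg in this assay, at which 1 of the 3 values shown sits. This chain had so far shown only a 1.5-fold lower number from compound 1 to compound 2 (0.16 log units; within the scatter), but it now shows large steps: an at least 76-fold higher number from compound 2 to compound 3 (1.88 log units; beyond the scatter) with undecyl in place of hydrogen, and an at least 52-fold higher number from compound 1 to compound 3 (1.72 log units; beyond the scatter) with decyl in place of hydrogen. The two shorter compounds alone gave no sign of it, but the length of this chain can matter greatly for the dose needed in this assay.

The compounds shown leave open at which intermediate chain length the number begins to rise, and whether it climbs gradually or abruptly. They also leave open how a shorter chain, or a chain ending in an amine or a carboxylic acid, would behave at this place.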